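The compounds below may be only part of what the source reports. "The series", "measured", "known", "first", "only" and "open" are said of these compounds alone.

Compound 1 `O=C(Nc1cccc(-n2cc(-c3ccncc3)c(-c3ccc(Cl)c(O)c3)n2)c1)Nc1cccc(C(F)(F)F)c1` carries a hydroxy group on its chloro-substituted ring. In a functional assay on COLO 205 cells (Homo sapiens) for inhibition, read by sulforhodamine B assay, with a stated time of 48 h (a higher number here means that more compound is tolerated, a lower number that less compound is tolerated), compound 1 gives > 32500 nM, which is a limit of the assay rather than a number. Compound 3 `COc1cc(-c2nn(-c3cccc(NC(=O)Nc4cccc(C(F)(F)F)c4)c3)cc2-c2ccncc2)ccc1Cl`, with methoxy in place of that hydroxy, gives 3430 nM in this assay. Compound 2 `COc1cc(-c2nn(-c3cccc(NC(=O)Nc4cc(C(F)(F)F)cc(C(F)(F)F)c4)c3)cc2-c2ccncc2)ccc1Cl`, which adds a second trifluoromethyl to the urea-bearing ring, gives 2910 nM. Compound 2 thus provides the smaller of the two numbers available, yet the step of a 1.2-fold higher number from compound 2 to compound 3 (0.07 log units; within the scatter) lies within the scatter, so compound 2 and compound 3 cannot be told apart on these data.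

Compound 4 `O=C(Nc1cccc(-n2cc(-c3ccncc3)c(-c3ccc(Cl)c(O)c3)n2)c1)Nc1cc(C(F)(F)F)cc(C(F)(F)F)c1` differs from compound 2 by hydrogen in place of methyl on an oxygen on an aromatic ring. Among the measured compounds shown here, the one measured step bearing on this is its reverse, an at least 9.4-fold lower number from compound 1 to compound 3 (0.97 log units; beyond the scatter), where compound 1 sits at the limit of > 32500 nM in this assay, at which 1 of the 3 values shown sits. Running the same change backwards from compound 2, the expected step is a 10-fold higher number from compound 2 to compound 4 (1.01 log units; beyond the scatter), a higher number and at least a modest one, with a real chance that compound 4 again reaches only a limit. Compound 4 is therefore estimated at 30000 nM, between 10000 nM and 90000 nM.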

Compound 4, concentration lethal to 50% of the cells: 2920 nM
Beside the measured number, compound 4's estimate is 10-fold (1.01 log units) above it; measured number outside the range, below it.
By their numbers in this assay, from the lowest: compounds 2, 4 and 3 (each within the scatter of the next). At a limit, above all of these: compound 1.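

Methoxy to hydroxy, a change that mattered between compound 3 and compound 1, leaves no measurable difference in this assay when the second trifluoromethyl is present, as seen in a 1.0-fold higher number from compound 2 to compound 4 (0.00 log units; within the scatter). On the hydroxy compounds, however, that trifluoromethyl does make a difference, an at least 11-fold lower number from compound 1 to compound 4 (1.04 log units; beyond the scatter), though this step starts from a limit of the assay rather than a number. The high number therefore belongs to compound 1 alone and does not follow the hydroxy group wherever it goes, so the size of this change depends on the core: the same change on two cores in this assay, an at least 9.4-fold lower number (0.97 log units; beyond the scatter) from compound 1 to compound 3 and a 1.0-fold lower number (0.00 log units; within the scatter) from compound 4 to compound 2, at least 9.4-fold (0.97 log units) apart, beyond the scatter of two such steps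

From the compounds shown here alone, it remains open whether an ethyl group or a longer chain on that oxygen, or an amine in place of the hydroxy, would behave like methoxy or hydroxy on either core. Going by these compounds, it is also open how a nitrile in place of the second trifluoromethyl would read.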